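A few compounds are considered here, and "the series" means these few. Any claim that something is new, unique, unknown or untested is made for them only; others in the source may bear on it.

Measured in an ADME assay on THP-1 cells (Homo sapiens) for cytotoxicity, read by flow cytometry and propidium iodide staining, with a stated time of 72 h; a lower number here means a stronger inhibitor, a higher number a weaker inhibitor:
- compound 1 `CC(=O)Nc1ccc2oc(-c3ccccc3F)c(O)c(=O)c2c1`: 47000 nM
- compound 2 `CC(=O)Nc1ccc2oc(-c3cccc(F)c3)c(O)c(=O)c2c1`: 36000 nM

Going by the values given here, compound 2 stands within the scatter of compound 1, the only other measured compound, so the two cannot be ranked. Compound 3 `CC(=O)Nc1ccc2oc(-c3ccc(F)cc3)c(O)c(=O)c2c1` follows with 4-fluorophenyl in place of 3-fluorophenyl on an aromatic carbon. Among the compounds with values here, the one measured step of this kind, from 2-fluorophenyl to 3-fluorophenyl, is a 1.3-fold lower number from compound 1 to compound 2 (0.12 log units; within the scatter). No step beyond the scatter is therefore expected in this assay.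

The expected step is a 1.1-fold higher number from compound 2 to compound 3 (0.02 log units; within the scatter).

Compound 3 is estimated at 38000 nM, with an expected range of 18000 nM to 75000 nM.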

Compound 3, half-maximal inhibitory concentration: 26000 nM
Compound 3: middle estimate off by 1.5-fold (0.16 log units), on the high side, and the stated range covers the measured number.
By their numbers in this assay, from the lowest: compounds 3, 2 and 1 (each within the scatter of the next).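

In this assay, the fluorine shift to 4-fluorophenyl gives a 1.4-fold lower number from compound 2 to compound 3 (0.14 log units; within the scatter), and the wider comparison with 2-fluorophenyl gives a 1.8-fold lower number from compound 1 to compound 3 (0.26 log units; within the scatter). All three fluorophenyl groups at this aromatic carbon therefore lie within the scatter of one another, so no preference among them can be read from this series. No measurement shown accounts for these numbers. Still open, as far as these compounds go, is whether a different group at this carbon, such as a pyridine or a phenyl carrying an amine or a carboxylic acid, would give a step beyond the scatter.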